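Geranylgeranyl purine oximes: methoxy to benzyloxy

The source may report more compounds than this note shows. Statements on the series, on what has been measured and on what is new or still open speak of the compounds shown alone.

The series holds two measured compounds and one open one. In a functional assay on ACHN cells (Homo sapiens) for cytotoxicity (on this read-out lower numbers stand for stronger inhibition and higher numbers for weaker inhibition), compound 1 `CO/N=c1\[nH]cnc2c1[n+](C/C=C(\C)CC/C=C(\C)CC/C=C(\C)CCC=C(C)C)cn2C(c1ccccc1)c1ccccc1` gives 4750 nM. In this assay, among the measured compounds shown here, compound 2 `CO/N=c1\[nH]cnc2ncn(C/C=C(\C)CC/C=C(\C)CC/C=C(\C)CCC=C(C)C)c12` gives 18100 nM, the highest of the two numbers; the gap to compound 1 lies beyond the scatter, but the two structures differ in more than one place, so no single-point step can be drawn from them. Compound 3 `CC(C)=CCC/C(C)=C/CC/C(C)=C/CC/C(C)=C/Cn1cnc2nc[nH]/c(=N\OCc3ccccc3)c21` is the unmeasured member. It differs from compound 2 by phenyl in place of hydrogen on a saturated chain carbon bound to an oxygen. For the measured compounds named here, nothing among the measured pairs isolates this change, and the only other compound, compound 1, carries its aromatic rings together with a further alteration of the shared core, so its value cannot be read as a guide. The expected step from compound 2 to compound 3 is therefore small and of uncertain direction, a 1.5-fold lower number from compound 2 to compound 3 (0.18 log units; within the scatter), most likely not beyond the scatter. For compound 3 in this assay the estimate is 12000 nM, within a range from 4000 nM to 40000 nM.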

Compound 3, half-maximal inhibitory concentration: 27400 nM
Estimate against measurement, compound 3: 2.3-fold (0.36 log units) below, within the range that was stated.
By their numbers in this assay, from the lowest: compound 1; then compounds 2 and 3 (each within the scatter of the next).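

Among the compounds shown here, the first single-point step reads a 1.5-fold higher number from compound 2 to compound 3 (0.18 log units; within the scatter) in this assay, for phenyl in place of hydrogen on a saturated chain carbon bound to an oxygen. At this place, methoxy to benzyloxy adds one six-membered aromatic ring of carbon only, and the read-out stays within the scatter, so this single step shows no separable effect of the phenyl. Compound 1 differs from compound 2 in more than one place, so no step to it can be read, and this result does not show which of its alterations accounts for its value.

No measurement at hand bears on why the change leaves the read-out within the scatter.

From the compounds shown here alone, it remains open whether a phenyl carrying an amine or a carboxylic acid, or a longer chain in place of the benzyl, would move the number beyond the scatter. Going by these compounds, it is also open whether methoxy to benzyloxy would read the same on the altered core of compound 1, where a single-point partner would be needed to isolate the change.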